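From chloro to propargyloxy on compound 1

The source may hold more compounds than are shown below. What is called first, only, known or untested is meant among the compounds shown, and "the series" means these compounds.

Measured so far in an ADME assay on LLC-PK1 cells (Sus scrofa) for permeability; a lower number here means that the compound crosses the layer more slowly, a higher number that the compound crosses the layer faster:
- compound 1 `COC[C@]12C[C@H]1[C@@](C)(c1cc(NC(=O)c3ccc(Cl)cn3)cc(F)c1F)N=C(N)S2` gives 13 10^-6 cm/s
- compound 2 `C[C@]1(c2cc(NC(=O)c3ccc(Cl)cn3)cc(F)c2F)N=C(N)S[C@@]2(C(N)=O)C[C@H]21` gives 38 10^-6 cm/s
- compound 3 `C[C@]1(c2cc(NC(=O)c3ccc(Cl)cn3)cc(F)c2F)N=C(N)S[C@@]2(C#N)C[C@H]21` gives 39 10^-6 cm/s

Of the three, compound 1 holds the lowest number in this assay, and both other compounds lie beyond the scatter from it. Compound 4 `C#CCOc1ccc(C(=O)Nc2cc(F)c(F)c([C@@]3(C)N=C(N)S[C@@]4(COC)C[C@H]43)c2)nc1` keeps the core of compound 1 but carries propargyloxy in place of chloro on an aromatic carbon. Going by the values given here, no measured step touches that place. The steps at hand all concern a saturated ring carbon: two are modest (a 2.9-fold higher number from compound 1 to compound 2 (0.47 log units; beyond the scatter); a 3.0-fold higher number from compound 1 to compound 3 (0.48 log units; beyond the scatter)), and the third stays within the scatter (a 1.0-fold higher number from compound 2 to compound 3 (0.01 log units; within the scatter)). They show that the read-out can move modestly with a change elsewhere in the molecule, but they give no direction for this one. The estimate therefore starts from the value of compound 1 (13 10^-6 cm/s), and no step beyond the scatter is expected (no change at the digits printed from compound 1 to compound 4 (within the scatter)). Compound 4 is estimated at 13 10^-6 cm/s, with an expected range from 6 10^-6 cm/s to 28 10^-6 cm/s.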

Compound 4, apparent permeability: 14 10^-6 cm/s
Compound 4: the middle estimate sits 1.1-fold (0.03 log units) below what was measured, and the stated range covers the measured number.
By their numbers in this assay, from the lowest: compounds 1 and 4 (each within the scatter of the next); then compounds 2 and 3 (each within the scatter of the next).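

In this assay, going by these compounds alone, the exchange of 5-chloropyridin-2-yl for 5-(propargyloxy)pyridin-2-yl gives a 1.1-fold higher number from compound 1 to compound 4 (0.03 log units; within the scatter), so this place, on an aromatic carbon two atoms from the ring nitrogen, now has a measured step, whereas the earlier steps all concerned a saturated ring carbon. Propargyloxy brings 4 heavy atoms, a triple bond and a hydrogen-bond acceptor in place of a single chlorine, and the step still lies within the scatter, unlike the two modest steps away from methoxymethyl. Nothing shown gives a reason for this result.

A single change at this place cannot tell whether an amine, a carboxylic acid or a longer ether chain there would also stay within the scatter of compound 1. As far as these compounds go, it also remains open whether propargyloxy would give a similar step with carbamoyl as in compound 2 or with cyano as in compound 3 on the saturated ring carbon.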